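This account rests on a few compounds, and the source may have more. Where it says the series, first, only, none or still open, it means among the compounds named here.

Compound 2 `N#CC1=C(N)OC(c2c[nH]c3ccccc23)=C(C#N)C1c1ccc(Br)cc1` gives 22.7% in a functional assay, tested at 400 ug/mL (a higher number here means a stronger effect of the compound at the concentration tested, a lower number a weaker effect), the highest of the two numbers recorded there; compound 3 `Cc1ccc(C2C(C#N)=C(N)OC(c3c[nH]c4ccccc34)=C2C#N)cc1` gives 8.5%, and compound 1 `N#CC1=C(N)OC(c2c[nH]c3ccccc23)=C(C#N)C1c1ccccc1F` is reported only as "not active" (no number reported). For the measured compounds named here, the one measured step, a number 14.2 percentage points lower from compound 2 to compound 3 (beyond the scatter), is modest and lies beyond the scatter.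

Compound 4 `N#CC1=C(N)OC(c2c[nH]c3ccccc23)=C(C#N)C1c1cccc2ccccc12` differs from compound 2 by naphthalen-1-yl in place of 4-bromophenyl on a saturated ring carbon. Going by the values given here, only the step from compound 2 to compound 3 touches the same group, and it lowered the read-out; no measured pair shows a ring of this size entering. Compound 4 is therefore expected to show a step of roughly a number 4.7 percentage points lower from compound 2 to compound 4 (within the scatter), with wide uncertainty, and its estimated value is 18%, ranging from 5% to 35%.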

Compound 4, a percentage reported as activity, at one concentration (the size of the read-out at that concentration, not a potency): 10.4%
For compound 4 the middle estimate is 7.6 percentage points above the measured one; low and high end bracket the measured number.
By their numbers in this assay, from the lowest: compounds 3 and 4 (each within the scatter of the next); then compound 2.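

Naphthalen-1-yl in place of 4-bromophenyl on this saturated ring carbon brings a number 12.3 percentage points lower from compound 2 to compound 4 (beyond the scatter) in this assay and so shows that a second six-membered aromatic ring here does not keep the read-out of compound 2. Set against 4-methylphenyl, the same group brings a number 1.9 percentage points higher from compound 3 to compound 4 (within the scatter) and leaves the two apart by no real margin. Among the numbers at this position, only the 4-bromophenyl of compound 2 stands clear of the others.

Going by these compounds, whether an amine or a carboxylic acid on the phenyl ring would raise the read-out remains open. Nothing here gives a reason for either step.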